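Swapping the ring-nitrogen substituent in an amide series

The compounds below may be only part of what the source reports. "The series", "measured", "known", "first", "only" and "open" are said of these compounds alone.

Compound 1 `Cc1c(C(=O)Nc2ccc(C(F)(F)F)cc2)cnn1Cc1ccc(F)cc1` gives 3600 nM in a functional assay with Homo sapiens as the target; on this read-out higher numbers stand for weaker inhibition and lower numbers for stronger inhibition.
Compound 2 `Cc1c(C(=O)Nc2ccccc2F)cnn1-c1ccc(F)cc1` gives 4000 nM in this assay.
Compound 3 `CCCCC(CC)NC(=O)c1cnn(-c2ccc(F)cc2)c1C` gives 580 nM in this assay.

Among these three numbers compound 1 stands second highest; compound 2 sits within the scatter of it, whereas compound 3 sits well below it. Among the measured compounds shown here, the one step between measured compounds that differ in a single place is a 6.9-fold lower number from compound 2 to compound 3 (0.84 log units; beyond the scatter), and it concerns the amide side of the shared core, not the aromatic nitrogen.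

Compound 4 `COc1cccc(-n2ncc(C(=O)Nc3ccc(C(F)(F)F)cc3)c2C)c1` differs from compound 1 at that aromatic nitrogen: 3-methoxyphenyl in place of 4-fluorobenzyl on an aromatic nitrogen. For the measured compounds named here, no measured step bears on a change of this kind. Compounds 1 and 2 do differ at the aromatic nitrogen, but they differ at the amide as well, so their two close values cannot be assigned to either change alone. With nothing to guide direction, the expected change is none beyond the scatter, that is a 1.1-fold lower number from compound 1 to compound 4 (0.05 log units; within the scatter). Compound 4 is therefore estimated at 3200 nM, within a range of 1000 nM to 10000 nM.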

Compound 4, half-maximal inhibitory concentration: 2500 nM
Compound 4: middle estimate off by 1.3-fold (0.11 log units), on the high side, and the stated range covers the measured number.
By their numbers in this assay, from the lowest: compound 3; then compounds 4, 1 and 2 (each within the scatter of the next).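

Among the compounds shown here, the step of a 1.4-fold lower number from compound 1 to compound 4 (0.16 log units; within the scatter) is the first reading at the aromatic nitrogen with the amide held constant, which the pair of compound 1 and compound 2 could not give. On the amide of compound 1, then, 3-methoxyphenyl and 4-fluorobenzyl read alike in this assay, even though the entering group brings a hydrogen-bond acceptor that the leaving group lacks, so this position has so far tolerated the exchange within the scatter. No supporting data are available to explain why these two groups give such similar readings.

On these data alone, whether 3-methoxyphenyl would behave the same way on the 1-ethylpentyl amide of compound 3 remains open. So does the question of whether an amine, a carboxylic acid or a simple butyl chain on the aromatic nitrogen would leave the number just as unmoved.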